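Cytotoxicity notes on a thiosemicarbazone isatin series

The compounds below may be only part of what the source reports. "The series", "measured", "known", "first", "only" and "open" are said of these compounds alone.

Measured compounds in an ADME assay on HeLa cells (Homo sapiens) for cytotoxicity; a higher number here means that more compound is tolerated, a lower number that less compound is tolerated:
compound 1 `CCN(CC)CN1C(=O)/C(=N/NC(=S)Nc2ccc(OC)cc2)c2ccccc21` gives >= 4000 nM, a limit of the assay rather than a number.
compound 2 `CCN(CC)CN1C(=O)/C(=N/NC(=S)Nc2ccc(C)cc2)c2ccccc21` gives >= 20000 nM, likewise a limit.
compound 3 `CCN(CC)CN1C(=O)/C(=N/NC(=S)Nc2ccc(OC)cc2)c2cc(Cl)ccc21` gives 4000 nM.

Among the measured compounds shown here, compound 3 carries the only number in this assay; the two other values are limits. The change from compound 1 to compound 2 is methyl in place of methoxy on an aromatic carbon and gives a step that the two limits leave unreadable from compound 1 to compound 2, which stays unreadable because the limit of >= 20000 nM in this assay, at which 1 of the 3 values shown sits, and the limit of >= 4000 nM in this assay, at which 1 of the 3 values shown sits, both stand at limits. The cores of compound 1 and compound 3 differ by chloro in place of hydrogen on an aromatic carbon, and the step reads a number no higher from compound 1 to compound 3 (the limit leaves the size open).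

Compound 4 `CCN(CC)CN1C(=O)/C(=N/NC(=S)Nc2ccc(C)cc2)c2cc(Cl)ccc21` is not yet measured in this assay. It differs from compound 3 by methyl in place of methoxy on an aromatic carbon, the same change as from compound 1 to compound 2, since the two place descriptions agree word for word. The earlier instance of this change left its size unreadable, so the expectation for compound 4 rests on compound 3 alone; compound 2 with its limit only shows that the methyl compound on the unsubstituted core was tolerated up to that limit.

Compound 4 is expected to come out near compound 3, with a step of a 2.0-fold higher number from compound 3 to compound 4 (0.30 log units; within the scatter) estimated. The estimate for compound 4 is 8000 nM, within an expected range from 3000 nM to 25000 nM.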

Compound 4, minimum cytotoxic concentration: >= 4000 nM
Compound 4 was reported as a limit; the forecaster's own chance of this, stated with the estimate: 40%; the middle value lies beyond the limit too.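

In this assay compound 4 gives >= 4000 nM, a limit of the assay and not a number. Methyl in place of methoxy on the core of compound 3 gives a number no lower from compound 3 to compound 4 (the limit leaves the size open), so on this core the change shows a direction that is bounded on one side, with no drop in the number tolerated and no measurable size. The other steps cannot be read, including the same change on the core of compound 1 and chloro in place of hydrogen between the two methyl compounds, so the data neither show that the effect of the change carries from one core to the other nor show that it fails to carry: the limit of >= 4000 nM in this assay, at which 2 of the 4 values shown sit.

Still open, from the compounds shown here alone, is where the methyl compounds on either core would read as actual numbers, and so whether chloro in place of hydrogen matters at all when methyl is present. Also open, going by these compounds, is how other groups would read in the same place on the aromatic ring, such as trifluoromethyl, a carboxylic acid or an amine, and how bromo would read in place of chloro on the core.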